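This account rests on a few compounds, and the source may have more. Where it says the series, first, only, none or still open, it means among the compounds named here.

Going by the values given here, in a functional assay on HeLa cells (Homo sapiens) for cytotoxicity, read by MTT assay, with a stated time of 24 h (on this read-out lower numbers stand for stronger inhibition and higher numbers for weaker inhibition), two compounds sharing the same core have numbers so far. Compound 1 `C/C(=N\NC(=O)/C(C#N)=C/c1ccc(O)cc1)c1c(O)c2ccc(O)cc2oc1=O` gives 6020 nM, and compound 2 `C/C(=N\NC(=O)/C(C#N)=C/c1ccc(N(C)C)cc1)c1c(O)c2ccc(O)cc2oc1=O` gives 5140 nM. These two values lie within the scatter of each other, so compound 2 cannot be ranked against compound 1.

Compound 3 `C/C(=N\NC(=O)/C(C#N)=C/c1ccccc1[N+](=O)[O-])c1c(O)c2ccc(O)cc2oc1=O` has not yet been measured. Its difference from compound 2 is 2-nitrophenyl in place of 4-(dimethylamino)phenyl on a double-bonded chain carbon bound to a double-bonded chain carbon. Put simply, 2-nitrophenyl stands in place of 4-(dimethylamino)phenyl on a double-bonded chain carbon bound to a double-bonded chain carbon.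

Among the compounds with values here, only one measured step bears on this change: a 1.2-fold lower number from compound 1 to compound 2 (0.07 log units; within the scatter), with dimethylamino in place of hydroxy on an aromatic carbon. Within the data shown here, that step stayed within the scatter, but it is a single example, and no measured compound carries a nitro group. The numbers therefore point in no direction, and no shift beyond the scatter is expected in this assay. The expected step is a 1.0-fold lower number from compound 2 to compound 3 (0.01 log units; within the scatter). With so little evidence, the range must stay wide. For compound 3 the estimated value is 5000 nM, with an expected range from 1800 nM to 14000 nM.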

Compound 3, half-maximal inhibitory concentration: 10300 nM
Estimate against measurement, compound 3: 2.1-fold (0.31 log units) below, and the stated range covers the measured number.
By their numbers in this assay, from the lowest: compounds 2, 1 and 3 (each within the scatter of the next).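

In this assay, the group on a double-bonded chain carbon bound to a double-bonded chain carbon has now been exchanged for a different kind of aromatic group, giving a 2.0-fold higher number from compound 2 to compound 3 (0.30 log units; within the scatter) and, in the second comparison, a 1.7-fold higher number from compound 1 to compound 3 (0.23 log units; within the scatter) as the listed steps. Both steps stay within the scatter, so 4-hydroxyphenyl, 4-(dimethylamino)phenyl and 2-nitrophenyl cannot be told apart at this place, even though 2-nitrophenyl brings a nitro group that neither earlier compound carries. No other measurement on these compounds helps to interpret this result.

The compounds shown leave open whether a carboxylic acid or a trifluoromethyl group on this aromatic ring would give a step beyond the scatter. On these data alone, it also remains open how much the nitro group itself and its numbered place on the ring each contribute, as the names 2-nitrophenyl and 4-(dimethylamino)phenyl show that both the group and its number differ in a single step.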